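The source may hold more compounds than are shown below. What is called first, only, known or untested is meant among the compounds shown, and "the series" means these compounds.

Measured so far in an assay on HEK293 cells for inhibition of Voltage-dependent T-type calcium channel subunit alpha-1G (Homo sapiens), read by fluorescence, tested at 10 uM; on this read-out higher numbers stand for more inhibition at the one concentration tested (going by the name of the read-out) and lower numbers for less inhibition:
compound 1 `CCCc1nc(-c2ccccc2)c(CNCCCN2CCN(c3cccc(F)c3)CC2)o1` gives 68.9%
compound 2 `CCCc1nc(-c2ccccc2)c(CNCCCN2CCN(c3ccccc3Cl)CC2)o1` gives 64.7%
compound 3 `CCCc1nc(-c2ccccc2)c(CNCCCN2CCN(c3cccc(Cl)c3)CC2)o1` gives 65.9%

Compound 3 stands second highest of these three numbers, yet its distance to each neighbour lies within the scatter, so no order can be read from them. Compound 4 `CCCc1nc(-c2ccccc2)c(CNCCCN2CCN(c3ccc(Cl)cc3)CC2)o1` differs from compound 3 by 4-chlorophenyl in place of 3-chlorophenyl on an amine nitrogen in a ring. The earlier steps shown here that changed the same group in the same place bear on this: a number 1.2 percentage points higher from compound 2 to compound 3 (within the scatter) and a number 3 percentage points lower from compound 1 to compound 3 (within the scatter). Both stayed within the scatter, so for this change too no shift beyond the scatter is expected in this assay. Compound 4 is therefore estimated at 66%, with a range from 55% to 77%. The expected step is a number 0.1 percentage points higher from compound 3 to compound 4 (within the scatter).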

Compound 4, a percentage reported as inhibition, at one concentration (the size of the read-out at that concentration, not a potency): 63.3%
The estimate for compound 4 lay 2.7 percentage points above the measured number, within the range that was stated.
By their numbers in this assay, from the lowest: compounds 4, 2, 3 and 1 (each within the scatter of the next).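

In this assay, 4-chlorophenyl on the amine nitrogen in the ring now joins 2-chlorophenyl and 3-chlorophenyl, and the step to it from either stays within the scatter (a number 2.6 percentage points lower from compound 3 to compound 4 (within the scatter); a number 1.4 percentage points lower from compound 2 to compound 4 (within the scatter)). The step from the 3-fluorophenyl compound also stays within it (a number 5.6 percentage points lower from compound 1 to compound 4 (within the scatter)), so these four aryl groups cannot be told apart here. No measurement at hand offers a reason for this. Open, going by these compounds, is whether a methoxy group, a nitrile or a carboxylic acid on this phenyl ring would give a step beyond the scatter.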